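The compounds below may be only part of what the source reports. "The series", "measured", "known", "first", "only" and "open" are said of these compounds alone.

Series in a functional assay on MCF7 cells (Homo sapiens) for cytotoxicity, read by MTT assay, with a stated time of 72 h; on this read-out higher numbers stand for weaker inhibition and lower numbers for stronger inhibition
- compound 1 `N#Cc1ccc(/C=N/NC(=O)Nc2cc3c(Nc4ccc(F)c(Cl)c4)ncnc3cc2O[C@H]2CCOC2)cc1` gives "not determined" (no result reported)
- compound 2 `O=C(N/N=C/c1ccc([N+](=O)[O-])cc1)Nc1cc2c(Nc3ccc(F)c(Cl)c3)ncnc2cc1O[C@H]1CCOC1` gives "not active" (no number reported)
- compound 3 `O=C(N/N=C/c1ccc(F)cc1Cl)Nc1cc2c(Nc3ccc(F)c(Cl)c3)ncnc2cc1O[C@H]1CCOC1` gives 32200 nM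

Going by the values given here, compound 3 at 32200 nM holds the only number, so it cannot be ranked against a measured neighbour. The change to compound 4 `COc1ccc(/C=N/NC(=O)Nc2cc3c(Nc4ccc(F)c(Cl)c4)ncnc3cc2O[C@H]2CCOC2)c(OC)c1OC` is 2,3,4-trimethoxyphenyl in place of 2-chloro-4-fluorophenyl on a carbon with a double bond to nitrogen with the shared core untouched. Among the compounds with values here, the series offers no measured step to size this change, so in this assay no step beyond the scatter is expected, in either direction. Compound 2 reads "not active" (no number reported) here, so a result without a number remains possible for compound 4. The expected step of a 1.1-fold lower number from compound 3 to compound 4 (0.03 log units; within the scatter) is small. For compound 4 the estimated value is 30000 nM with an expected range of 10000 nM to 90000 nM in this read-out.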

Compound 4, half-maximal inhibitory concentration: 33800 nM
For compound 4 the middle estimate is 1.1-fold (0.05 log units) below the measured one, and the stated range covers the measured number.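

In this assay, going by these compounds alone, the change at this carbon with a double bond to nitrogen gives a 1.0-fold higher number from compound 3 to compound 4 (0.02 log units; within the scatter), the first measured step. The read-out therefore does not separate 2-chloro-4-fluorophenyl from 2,3,4-trimethoxyphenyl, although the entering group brings three hydrogen-bond acceptors. No measurement at hand explains this result.

Steps involving compound 1 and compound 2 cannot be read. Open, on these data alone, is whether a phenyl ring carrying an amine or a carboxylic acid at this place would give a step beyond the scatter.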